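The source may hold more compounds than are shown below. What is called first, only, known or untested is meant among the compounds shown, and "the series" means these compounds.

Compound 1 `Oc1ccc2ccccc2c1C(Nc1nc2ccccc2s1)c1cn(-c2ccccc2)nc1-c1ccccc1`: 48900 nM
Compound 2 `COc1cccc(-c2nn(-c3ccccc3)cc2C(Nc2nc3ccccc3s2)c2c(O)ccc3ccccc23)c1`: 16900 nM
Compound 3 `Cc1cccc(-c2nn(-c3ccccc3)cc2C(Nc2nc3ccccc3s2)c2c(O)ccc3ccccc23)c1`: 17300 nM

In a functional assay on MCF7 cells (Homo sapiens) for antiproliferative activity, read by MTT assay, with a stated time of 48 h (on this read-out lower numbers stand for stronger inhibition and higher numbers for weaker inhibition), compound 3 stands well under compound 1 and level with compound 2, as shown by a 1.0-fold higher number from compound 2 to compound 3 (0.01 log units; within the scatter). Compound 4 `O=[N+]([O-])c1ccc(-c2nn(-c3ccccc3)cc2C(Nc2nc3ccccc3s2)c2c(O)ccc3ccccc23)cc1` carries 4-nitrophenyl in place of 3-methylphenyl on an aromatic carbon of a five-membered aromatic ring with 2 nitrogen: 4-nitrophenyl in place of 3-methylphenyl on an aromatic carbon.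

Two modest steps bear on this change: a 2.9-fold lower number from compound 1 to compound 2 (0.46 log units; beyond the scatter), and a 2.8-fold lower number from compound 1 to compound 3 (0.45 log units; beyond the scatter). Swapping methoxy for methyl gave no step beyond the scatter. Among the compounds with values here, no compound with 4-nitrophenyl has been measured, so this is a cautious guess: no step beyond the scatter is expected in this assay. Expected is a 1.1-fold lower number from compound 3 to compound 4 (0.03 log units; within the scatter). For compound 4 the estimated value is 16000 nM, with an expected range of 6000 nM to 45000 nM.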

Compound 4, half-maximal inhibitory concentration: 14700 nM
Compound 4: the middle estimate sits 1.1-fold (0.04 log units) above what was measured, and the stated range covers the measured number.
By their numbers in this assay, from the lowest: compounds 4, 2 and 3 (each within the scatter of the next); then compound 1.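

In this assay the 4-nitrophenyl group at this place gives a number level with those of the 3-methylphenyl group (a 1.2-fold lower number from compound 3 to compound 4 (0.07 log units; within the scatter)) and the 3-methoxyphenyl group (a 1.1-fold lower number from compound 2 to compound 4 (0.06 log units; within the scatter)). Adding nitro to the plain phenyl group of compound 1 also gives a modest step beyond the scatter (a 3.3-fold lower number from compound 1 to compound 4 (0.52 log units; beyond the scatter)), so all three substituted phenyl groups now sit below compound 1. Nothing measured here explains why these three groups give such similar numbers. Going by these compounds, whether an amine or a carboxylic acid on this phenyl ring would shift the number remains open, as does the effect of a longer chain in place of the ring.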